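The source may report more compounds than this note shows. Statements on the series, on what has been measured and on what is new or still open speak of the compounds shown alone.

Three compounds have been measured in an in vitro assay on cells for inhibition of Amine oxidase [flavin-containing] B (Homo sapiens), read by fluorescence and Amplex Red, with stated times of 30 min and 45 min; on this read-out lower numbers stand for stronger inhibition and higher numbers for weaker inhibition:
compound 1 `COc1cccc(CCCC(=O)Nc2nc3ccccc3c(=O)s2)c1` gives 389 nM.
compound 2 `O=C(C/C=C/c1cccc(Cl)c1)Nc1nc2ccccc2c(=O)s1` gives > 1000 nM, which is a limit of the assay and not a number.
compound 3 `COc1cccc(C#CC(=O)Nc2nc3ccccc3c(=O)s2)c1` gives 43.7 nM.

All three share the same core and differ only in the chain that links the amide to a phenyl ring, and in what that ring carries. Compound 1 stands highest of the two numbers that were actually obtained: compound 3 gives the lower number, and the gap between the two lies beyond the usual scatter of this assay. Compound 2 sits at the limit (the limit of > 1000 nM in this assay, at which 1 of the 3 values shown sits), so where it would fall beyond that line cannot be read off.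

Compound 4 `O=C(CCCc1ccc(Cl)c(Cl)c1)Nc1nc2ccccc2c(=O)s1` has not yet been measured. It is made from compound 1 by a single change: 3,4-dichlorophenyl in place of 3-methoxyphenyl on a saturated chain carbon, three bonds along the chain from a carbonyl carbon. Among the compounds with values here, no step between measured compounds matches this change, and the measured pairs say nothing about swapping a methoxy for chlorines. The expected step is therefore modest: from compound 1 the number for compound 4 is expected to move by a 1.1-fold lower number from compound 1 to compound 4 (0.05 log units; within the scatter), within the usual scatter in either direction. The estimate for compound 4 in this assay is 350 nM, with a range from 100 nM to 1200 nM.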

Compound 4, half-maximal inhibitory concentration: 3440 nM
For compound 4 the middle estimate is 9.8-fold (0.99 log units) below the measured one, and the stated range ends below it.
By their numbers in this assay, from the lowest: compound 3; then compound 1; then compound 4.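

In this assay, replacing 3-methoxyphenyl with 3,4-dichlorophenyl on a saturated chain carbon, three bonds along the chain from a carbonyl carbon, gives an 8.8-fold higher number from compound 1 to compound 4 (0.95 log units; beyond the scatter), which means weaker inhibition. Within the data shown here, the earlier compounds offered no pair differing in one place, so this is the first direct sign that, with the chain and the shared core held constant, what the phenyl ring carries at the end of this saturated chain matters to the read-out. Nothing measured among these compounds accounts for the size or direction of this step.

Going by these compounds, the step removes the methoxy and adds both chlorines at once, so it remains open whether the weaker inhibition follows from losing the methoxy, from adding the chlorines, or from both, and an unsubstituted phenyl ring or a ring carrying an amine on the same saturated chain would help to separate these possibilities. Compound 2 cannot settle this question, as its value is a limit and not a number: the limit of > 1000 nM in this assay, at which 1 of the 4 values shown sits.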